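The compounds below may be only part of what the source reports. "The series", "measured", "known", "first", "only" and "open" are said of these compounds alone.

Compound 1 `Cc1ccc(S(=O)(=O)N[C@@H](CC(=O)NC(C)(C)C)C(=O)NCCNC(=O)c2cccc(O)c2)cc1` belongs to a small set of three closely related compounds examined in an ADME assay on Karpas-1106P cells (Homo sapiens) for cytotoxicity; a lower number here means that less compound is needed, a higher number that more compound is needed for the effect. In this assay compound 1 gives no number but only a limit, > 11100 nM. Compound 2 `Cc1ccc(S(=O)(=O)N[C@@H](CC(=O)NC(C)(C)C)C(=O)NCCNC(=O)c2c(O)cccc2F)cc1` carries a 2-fluoro-6-hydroxyphenyl in place of the 3-hydroxyphenyl of compound 1, and in this assay compound 2 also reaches only a limit, > 11100 nM. Compound 3 `Cc1ccc(S(=O)(=O)N[C@@H](CC(=O)NC(C)(C)C)C(=O)NCCNC(=O)NCc2ccccc2)cc1` carries a benzylamino on the carbonyl carbon, and in this assay compound 3 again gives only a limit, > 11100 nM. The three steps between them are consequently unreadable: a step that the two limits leave unreadable from compound 1 to compound 2, a step that the two limits leave unreadable from compound 1 to compound 3 and a step that the two limits leave unreadable from compound 2 to compound 3. What the set does show is the limit of > 11100 nM in this assay, at which 3 of the 3 values shown sit.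

Compound 4 `Cc1ccc(S(=O)(=O)N[C@@H](CC(=O)NC(C)(C)C)C(=O)NCCNC(=O)c2cc(C)ccc2F)cc1` differs from compound 1 in a single place: 2-fluoro-5-methylphenyl in place of 3-hydroxyphenyl on a carbonyl carbon. For the measured compounds named here, no measured step gives a readable size, so the change offers no ground to expect any movement beyond the scatter in this assay. The step is therefore estimated as a step that the limit leaves unreadable from compound 1 to compound 4. Compound 4 is accordingly expected in this assay to give about 20000 nM, within a range from 8000 nM to 60000 nM, and most probably to be reported once more only as a limit rather than a number.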

Compound 4, half-maximal effective concentration: > 11100 nM
Compound 4 gave a limit, no number; the forecaster's own chance of this, stated with the estimate: 85%; the middle value lies beyond the limit too.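

In this assay compound 4 gives > 11100 nM, which is a limit and not a number. The steps linking compound 4 to compound 1, compound 2 and compound 3 therefore cannot be read. The compounds shown leave open whether the group on the carbonyl carbon changes the read-out at all, since the set shows only this: the limit of > 11100 nM in this assay, at which 4 of the 4 values shown sit.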